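The source may report more compounds than this note shows. Statements on the series, on what has been measured and on what is new or still open speak of the compounds shown alone.

Compound 1 `O=C1Nc2ccc(Br)cc2C1=Cc1ccco1` is one of two compounds that share a core and have been tested in an ADME assay on A549 cells (Homo sapiens) for cytotoxicity, read by MTT assay, with a stated time of 72 h; on this read-out higher numbers stand for weaker inhibition and lower numbers for stronger inhibition. In this assay, within the data shown here, compound 1 gives 449000 nM, and this is the only plain number among the two values shown, so compound 1 cannot be ranked against a second measured compound. Compound 2 `COC(=O)Nc1ccc2c(c1)C(=Cc1ccc([N+](=O)[O-])cc1)C(=O)N2` reaches only a limit of the assay in this assay, reported as > 100000 nM, which is the limit of > 100000 nM in this assay, at which 1 of the 2 values shown sits, so compound 2 gives no number to compare with.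

Compound 3 `O=C1Nc2ccc(Br)cc2C1=Cc1ccncc1` has not yet been measured. It differs from compound 1 in a single place: pyridin-4-yl in place of furan-2-yl on a double-bonded chain carbon bound to a double-bonded ring carbon. Among the measured compounds shown here, no measured pair shows what such an exchange does in this assay, so the size of the change has to be guessed from compound 1 alone. Both compounds shown sit at very weak inhibition, and compound 3 is expected to stay in that region, with a step from a 1.3-fold lower number from compound 1 to compound 3 (0.11 log units; within the scatter) that is estimated to lie within the usual scatter. Compound 3 is therefore expected to give about 350000 nM in this assay, with a likely range from 100000 nM to 1000000 nM.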

Compound 3, half-maximal inhibitory concentration: 22300 nM
The estimate for compound 3 lay 16-fold (1.20 log units) above the measured number; the whole stated range lies above it.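

In this assay, pyridin-4-yl in place of furan-2-yl on a double-bonded chain carbon bound to a double-bonded ring carbon gives a 20-fold lower number from compound 1 to compound 3 (1.30 log units; beyond the scatter), so this position can move the read-out strongly towards stronger inhibition. The two groups have the same counts of hydrogen-bond donors and acceptors and the same net charge, so those counts do not separate them; they differ in ring size and in the hetero atom, and this single pair cannot tell which of these differences matters. Compound 2 offers no number to set beside this pair, as its value is a limit of the assay: the limit of > 100000 nM in this assay, at which 1 of the 3 values shown sits.

The compounds shown leave open whether the step belongs to the six-membered ring as such or to its nitrogen, a question that a plain phenyl ring at this place would help to settle, and whether pyridin-3-yl would behave like pyridin-4-yl. They also leave open whether the exchange gives a step of similar size when the bromine on the shared core is replaced by another group, such as a methoxy group.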